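Series notes: oxolan-2-yl in place of methyl

The compounds below may be only part of what the source reports. "The series", "measured", "known", "first", "only" and "open" are said of these compounds alone.

Compound 3 `CCCc1nc2cc(Cl)c(Cl)cc2n1C` gives 24600 nM in a functional assay on HepG2 cells (Homo sapiens) for cytotoxicity (a higher number here means that more compound is tolerated, a lower number that less compound is tolerated), the second highest of the three numbers measured. Compound 1 `Cn1c(CCc2ccco2)nc2cc(Cl)c(Cl)cc21` gives 5900 nM and compound 2 `Cn1c(CCc2ccncc2)nc2cc(Cl)c(Cl)cc21` gives 35800 nM. Compound 4 `Cn1c(CCC2CCCO2)nc2cc(Cl)c(Cl)cc21` has not been measured; its change from compound 3 is oxolan-2-yl in place of methyl on a saturated chain carbon, two bonds along the chain from an aromatic carbon.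

The bearing steps: a 4.2-fold higher number from compound 1 to compound 3 (0.62 log units; beyond the scatter) and a 1.5-fold lower number from compound 2 to compound 3 (0.16 log units; within the scatter). The former shows that removing the furan-2-yl toward methyl raised the tolerated concentration; oxolan-2-yl is the closest measured relative of furan-2-yl, so a modest step in the opposite direction is expected, a 2.1-fold lower number from compound 3 to compound 4 (0.31 log units; beyond the scatter). Compound 4 is therefore estimated at 12000 nM, with a range of 5000 nM to 30000 nM.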

Compound 4, half-maximal cytotoxic concentration: 56000 nM
Compound 4: the middle estimate sits 4.7-fold (0.67 log units) below what was measured; measured number outside the range, above it.
By their numbers in this assay, from the lowest: compound 1; then compounds 3, 2 and 4 (each within the scatter of the next, the first and the last beyond it).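

The oxolan-2-yl and furan-2-yl groups do not read alike at this position, with a 9.5-fold higher number from compound 1 to compound 4 (0.98 log units; beyond the scatter) between them. Against methyl, oxolan-2-yl gives a 2.3-fold higher number from compound 3 to compound 4 (0.36 log units; beyond the scatter) so a ring on this chain does not of itself bring the number down, while a 1.6-fold higher number from compound 2 to compound 4 (0.19 log units; within the scatter) leaves the oxolan-2-yl and pyridin-4-yl groups level within the scatter. No measurement at hand accounts for these differences.

Going by these compounds, an amine, a carboxylic acid or a longer chain at this place remains open. So does whether an open-chain ether such as methoxymethyl would read like oxolan-2-yl.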